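Moving a methyl group on a benzyl substituent

A few compounds are considered here, and "the series" means these few. Any claim that something is new, unique, unknown or untested is made for them only; others in the source may bear on it.

Of the compounds shown here, two have so far been measured in a functional assay on cells for positive allosteric modulation of G-protein coupled receptor 68 (Homo sapiens), read by a luciferase reporter and cAMP accumulation, with a stated time of 30 min, at pH 6.8 and pH 8.3, in the presence of a further agent that is not named here; on this read-out higher numbers stand for higher potency (the scale is a negative logarithm) and lower numbers for lower potency. Compound 1 `Nc1nc(NCc2cccc(F)c2)nc(-c2ccccc2CO)n1` gives 4.52 in this assay. Compound 2 `Cc1ccccc1CNc1nc(N)nc(-c2ccccc2CO)n1` carries a 2-methylphenyl where compound 1 carries a 3-fluorophenyl, on a saturated chain carbon bound to a nitrogen on an aromatic ring, and in this assay compound 2 gives 4.7. That single step, a number 0.18 log units higher from compound 1 to compound 2 (within the scatter), is within the scatter. Among the two measured compounds, compound 2 gives the larger number, yet the difference from compound 1 lies within the scatter, so the two cannot be told apart.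

Compound 3 `Cc1ccc(CNc2nc(N)nc(-c3ccccc3CO)n2)cc1` has the same atoms as compound 2, joined differently: 4-methylphenyl in place of 2-methylphenyl on a saturated chain carbon bound to a nitrogen on an aromatic ring. For the measured compounds named here, no measured step moves a methyl group on this ring in this way; the only step available, from compound 1 to compound 2, swaps one substituted ring for another and was within the scatter, so it bears on the present change only loosely. For compound 3 the expected step is therefore a number 0.10 log units lower from compound 2 to compound 3 (within the scatter), with no change beyond the scatter anticipated. The estimate for compound 3 is 4.6, with an expected range from 4.2 to 5.1.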

Compound 3, negative logarithm of the antagonist equilibrium constant: 4.38
The estimate for compound 3 lay 0.22 log units above the measured number; the measured number falls inside the stated range.
By their numbers in this assay, from the lowest: compounds 3, 1 and 2 (each within the scatter of the next, the first and the last beyond it).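

Moving the methyl group from 2-methylphenyl to 4-methylphenyl, on a saturated chain carbon bound to a nitrogen on an aromatic ring, gives a number 0.32 log units lower from compound 2 to compound 3 (beyond the scatter) in this assay, the first step in this small set to lie beyond the usual scatter. The two compounds have the same atoms, joined differently, so at this place the position of a single methyl group on the ring can shift the read-out, though only modestly. Exchanging 3-fluorophenyl for 4-methylphenyl gives a number 0.14 log units lower from compound 1 to compound 3 (within the scatter), so these two compounds cannot be told apart, and 2-methylphenyl and 4-methylphenyl each lie within the scatter of 3-fluorophenyl even though they differ from each other. No measurement shown here offers an explanation for the step caused by moving the methyl group.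

This rests on a single pair, so the compounds shown leave open whether moving a different group around the ring would produce a similar step. They also leave open how a ring carrying a methoxy group or an amine would read at this place, and what a longer chain would do in place of the single saturated chain carbon.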